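Shifting a Chlorine Substituent: Cytotoxicity Expectation for Compound 4

The source may report more compounds than this note shows. Statements on the series, on what has been measured and on what is new or still open speak of the compounds shown alone.

Measured compounds:
compound 1 `COc1ccc(-n2nnnc2Nc2ccccc2Cl)cc1`, 134000 nM
compound 2 `COc1ccc(Nc2nnnn2-c2cccc(Br)c2)cc1`, 107000 nM
compound 3 `COc1ccc(Nc2nnnn2-c2ccc(Cl)cc2)cc1`, 102000 nM

In an ADME assay on HaCaT cells (Homo sapiens) for cytotoxicity, read by MTT assay, with a stated time of 72 h (on this read-out higher numbers stand for weaker inhibition and lower numbers for stronger inhibition), compound 1 gives 134000 nM, the highest of the three numbers, yet its gaps to compound 2 and compound 3 both lie within the scatter, so none of the three can be called weaker or stronger than another. The new compound 4 `COc1ccc(-n2nnnc2Nc2cccc(Cl)c2)cc1` differs from compound 1 only in the chlorinated ring: 3-chlorophenyl in place of 2-chlorophenyl on a nitrogen on an aromatic ring.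

Within the data shown here, the one measured step that speaks to such a change is a 1.0-fold lower number from compound 2 to compound 3 (0.02 log units; within the scatter), where one halophenyl group replaced another on an aromatic nitrogen without any shift beyond the scatter. Together with the flat spread across compound 1, compound 2 and compound 3, this gives no reason to expect that moving the chlorine changes the read-out in this assay.

Among the measured compounds shown here, compound 4 is therefore expected to show essentially no step, a 1.1-fold lower number from compound 1 to compound 4 (0.05 log units; within the scatter), with an estimated value of 120000 nM and a range from 60000 nM to 240000 nM.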

Compound 4, half-maximal inhibitory concentration: 141000 nM
Compound 4: the middle estimate sits 1.2-fold (0.07 log units) below what was measured, within the range that was stated.
By their numbers in this assay, from the lowest: compounds 3, 2, 1 and 4 (each within the scatter of the next).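

In this assay, the change gives a 1.1-fold higher number from compound 1 to compound 4 (0.02 log units; within the scatter), so 3-chlorophenyl in place of 2-chlorophenyl on a nitrogen on an aromatic ring leaves the read-out within the scatter. Among these compounds, the earlier step exchanged one halophenyl group for another with a different halogen, whereas here the atoms stay the same and only their joining differs, so this is the first pair to test the place of the chlorine alone. Nothing at hand bears on why the read-out stays flat across this change.

On these data alone, all four compounds lie within the scatter of their neighbours, so it remains open whether any change at this place can move the read-out beyond the scatter. A phenyl ring carrying an amine or a carboxylic acid in place of the chlorine could test this.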